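Liver microsome half-life: from compound 2 to compound 3

The source may report more compounds than this note shows. Statements on the series, on what has been measured and on what is new or still open speak of the compounds shown alone.

Compound 2 `NS(=O)(=O)c1cc(-c2nnc(/C=C/c3c(Cl)cccc3Cl)o2)c(Cl)cc1SCc1ccccc1` holds the higher of the two half-lives measured in an ADME assay on microsomes from liver (Homo sapiens) for metabolic stability, read by LC-MS, using NADPH, tested at 5 uM (on this read-out lower numbers stand for a shorter-lived compound and higher numbers for a longer-lived compound), giving 0.468 h, while compound 1 `NS(=O)(=O)c1cc(-c2nnc(/C=C/c3ccc(Cl)cc3)o2)c(Cl)cc1SCc1ccccc1` gives 0.207 h. For the measured compounds named here, the only measured step, a 2.3-fold higher number from compound 1 to compound 2 (0.35 log units; beyond the scatter), replaced 4-chlorophenyl with 2,6-dichlorophenyl. Compound 3 `NS(=O)(=O)c1cc(-c2nnc(/C=C/c3ccc(Br)cc3)o2)c(Cl)cc1SCc1ccccc1` differs from compound 2 by 4-bromophenyl in place of 2,6-dichlorophenyl on a double-bonded chain carbon bound to a double-bonded chain carbon, which returns to a singly halogenated ring resembling that of compound 1. That step is therefore expected to run back in the opposite direction, a 2.1-fold lower number from compound 2 to compound 3 (0.33 log units; beyond the scatter), a modest move beyond the scatter. Compound 3 is estimated at 0.22 h, within 0.1 h to 0.5 h.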

Compound 3, half-life: 0.6 h
Compound 3: middle estimate off by 2.7-fold (0.44 log units), on the low side; the measured number lies above the stated range.
By their numbers in this assay, from the lowest: compound 1; then compounds 2 and 3 (each within the scatter of the next).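

In this assay, 4-bromophenyl in place of 2,6-dichlorophenyl on a double-bonded chain carbon bound to a double-bonded chain carbon gives a 1.3-fold higher number from compound 2 to compound 3 (0.11 log units; within the scatter) and so leaves the two groups indistinguishable. Bromo in place of chloro on an aromatic carbon gives a 2.9-fold higher number from compound 1 to compound 3 (0.46 log units; beyond the scatter) and shows that a ring with a single halogen can read as high as the 2,6-dichlorophenyl ring, depending on which halogen it carries. No evidence here accounts for this difference. The compounds shown leave open how 4-fluorophenyl or 4-methoxyphenyl would read at this place.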